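The source may hold more compounds than are shown below. What is called first, only, known or untested is meant among the compounds shown, and "the series" means these compounds.

Measured compounds, in an assay on HEK293-TREx cells for antagonist activity at transient receptor potential cation channel subfamily A member 1 (Homo sapiens), read by calcium flux; on this read-out lower numbers stand for stronger inhibition and higher numbers for weaker inhibition:

Compound 1, `O=C(Nc1cc(NCc2cccs2)cc(C(F)(F)F)c1)c1cccs1`: 2700 nM
Compound 2, `COC(=O)Nc1cc(NC(=O)c2cccs2)cc(C(F)(F)F)c1`: 2300 nM
Compound 3, `CCCNc1cc(NC(=O)c2ccccn2)cc(C(F)(F)F)c1`: > 32000 nM, which is a limit of the assay rather than a number.

Compound 3 therefore stands at the limit (the limit of > 32000 nM in this assay, at which 1 of the 3 values shown sits), the weakest place a value can be reported in this assay, and its true number is not known. Within the data shown here, only one step between measured compounds is available: a 1.2-fold lower number from compound 1 to compound 2 (0.07 log units; within the scatter). That step changed the group on the ring nitrogen and left the carbonyl side untouched, so it gives no direct guidance for a change at the carbonyl carbon.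

Compound 4, `CCCNc1cc(NC(=O)c2ccncc2)cc(C(F)(F)F)c1`, is the next compound and differs from compound 3 only in the ring attached to the carbonyl: pyridin-4-yl in place of pyridin-2-yl on a carbonyl carbon. The two compounds are built from the same atoms joined differently.

Among the measured compounds shown here, since no measured step touches this position, the expectation for compound 4 rests on compound 3 alone, and compound 4 is expected to remain close to where compound 3 stands, quite possibly again at the limit. The expected step of an at least 1.0-fold lower number from compound 3 to compound 4 (0.02 log units; that floor lies within the scatter) is thus one of no clear change beyond the scatter. The estimate for compound 4 in this assay is 30000 nM, with a range from 8000 nM to 100000 nM.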

Compound 4, half-maximal inhibitory concentration: 2600 nM
For compound 4 the middle estimate is 12-fold (1.06 log units) above the measured one; the measured number lies below the stated range.
By their numbers in this assay, from the lowest: compounds 2, 4 and 1 (each within the scatter of the next). At a limit, above all of these: compound 3.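

In this assay, among these compounds, the ring on the carbonyl carbon proves to be a position where the arrangement of atoms matters: pyridin-4-yl in place of pyridin-2-yl gives an at least 12-fold lower number from compound 3 to compound 4 (1.09 log units; beyond the scatter), whereas the only earlier step changed the group on the ring nitrogen and left this position untouched. The two rings count the same heavy atoms, the same single hetero atom and the same hydrogen-bond acceptor, so this gap arises with nothing added or removed, only the same atoms joined differently. The printed step is a floor rather than a full size, because compound 3 stands at a limit and not at a number: the limit of > 32000 nM in this assay, at which 1 of the 4 values shown sits.

As far as these compounds go, only these two rings can be compared directly at this position, so it remains open whether a phenyl ring, which has no hetero atom, would behave like pyridin-4-yl or like pyridin-2-yl on the same carbonyl carbon. Compound 4 also differs from compound 1 and compound 2 in more than one place, which leaves open whether pyridin-4-yl would keep this effect with a methoxycarbonyl group or a longer chain on the other nitrogen.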